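The source may hold more compounds than are shown below. What is called first, only, known or untested is meant among the compounds shown, and "the series" means these compounds.

Compound 1 `COc1ccc(-c2nc3cccc(-c4cc(OC)c(OC)c(OC)c4)c3o2)cc1` gives 2200 nM in a functional assay on A549 cells (Homo sapiens) for antiproliferative activity, read by MTT assay, with a stated time of 48 h (a higher number here means a weaker inhibitor, a lower number a stronger inhibitor), the lowest of the two numbers shown. Compound 2 `COc1cccc(-c2nc3cccc(-c4cc(OC)c(OC)c(OC)c4)c3o2)c1` gives 3500 nM in this assay, and the step of a 1.6-fold higher number from compound 1 to compound 2 (0.20 log units; within the scatter) lies within the scatter. For compound 3 `COc1cc(-c2cccc3nc(-c4ccc(Br)cc4)oc23)cc(OC)c1OC` this assay reports only a limit, > 25000 nM. The step of an at least 11-fold higher number from compound 1 to compound 3 (1.05 log units; beyond the scatter) was large, reaching that limit (the limit of > 25000 nM in this assay, at which 1 of the 3 values shown sits). Compound 4 `COc1cc(-c2cccc3nc(-c4ccc(C)cc4)oc23)cc(OC)c1OC` differs from compound 1 by methyl in place of methoxy on an aromatic carbon. The step from compound 1 to compound 3 is the closest guide, since it also changed the methoxy at this place, and it lost much; the step from compound 1 to compound 2 says little here. Compound 4 is therefore expected to show a weakening step, a 3.2-fold higher number from compound 1 to compound 4 (0.50 log units; beyond the scatter), smaller than that seen with bromo. Compound 4 is estimated at 7000 nM, between 2500 nM and 25000 nM.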

Compound 4, half-maximal inhibitory concentration: 680 nM
Estimate against measurement, compound 4: 10-fold (1.01 log units) above; the whole stated range lies above it.
By their numbers in this assay, from the lowest: compound 4; then compounds 1 and 2 (each within the scatter of the next). At a limit, above all of these: compound 3.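

Methoxy is not needed at this place, para to a large group: methyl there gives a 3.2-fold lower number from compound 1 to compound 4 (0.51 log units; beyond the scatter). The 4-methylphenyl group also separates clearly from the 3-methoxyphenyl group, with a 5.1-fold lower number from compound 2 to compound 4 (0.71 log units; beyond the scatter). Methyl and bromo, both entering in place of methoxy, part widely, with an at least 36-fold lower number from compound 3 to compound 4 (1.56 log units; beyond the scatter), a step that rests on a limit: the limit of > 25000 nM in this assay, at which 1 of the 4 values shown sits.

What the compounds shown leave open is whether the gain is particular to methyl or extends to an ethyl, a chloro, an amine or a carboxylic acid at this place.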